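The source may hold more compounds than are shown below. What is called first, only, known or untested is meant among the compounds shown, and "the series" means these compounds.

Measured in a functional assay on HepG2 cells (Homo sapiens) for cytotoxicity, with a stated time of 72 h (a lower number here means that less compound is needed, a higher number that more compound is needed for the effect), with every value a limit of the assay and not a number:
Compound 1 `C=C[C@@](C)(/C=C/c1ccc(OS(=O)(=O)c2ccc(C)cc2)cc1)CCC=C(C)C`: > 52000 nM
Compound 2 `C=C[C@@](C)(/C=C/c1ccc(O)c(/C=C/C(=O)c2ccccc2)c1)CCC=C(C)C`: > 52000 nM
Compound 3 `C=C[C@@](C)(/C=C/c1ccc(O)c(/C=C/C#N)c1)CCC=C(C)C`: > 52000 nM

Compound 3 has only a limit, > 52000 nM, so no number places it among the others. Compound 4 `C=C[C@@](C)(/C=C/c1ccc(O)c(/C=C/C(=O)O)c1)CCC=C(C)C` has carboxy in place of cyano on a double-bonded chain carbon bound to a double-bonded chain carbon. Within the data shown here, the one measured step that bears on this change is a step that the two limits leave unreadable from compound 2 to compound 3, and it offers no size to carry over. The other guide is the limit of > 52000 nM in this assay, at which 3 of the 3 values shown sit. The expected step is a step that the limit leaves unreadable from compound 3 to compound 4, with no clear direction and nothing expected beyond the scatter in this assay. For compound 4 the estimate is 60000 nM, with an expected range of 30000 nM to 120000 nM.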

Compound 4, half-maximal effective concentration: > 52000 nM
Compound 4 was reported as a limit; the forecaster's own chance of this, stated with the estimate: 85%; the middle value does not contradict the limit.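

The steps from compound 2 to compound 4 and from compound 3 to compound 4 cannot be read, as both ends of each are limits of the assay: the limit of > 52000 nM in this assay, at which 4 of the 4 values shown sit.

The compounds shown leave open whether cyano, carboxy or benzoyl on the chain changes the result in this assay.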